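The compounds below may be only part of what the source reports. "The series", "measured", "known", "first", "only" and "open" are said of these compounds alone.

Measured so far in a functional assay on LNCaP cells (Homo sapiens) for antiproliferative activity, read by propidium iodide staining, with a stated time of 96 h; on this read-out lower numbers stand for stronger inhibition and higher numbers for weaker inhibition:
compound 1, `CC(O)(CSc1ccc(S(F)(F)(F)(F)F)cc1)C(=O)Nc1ccc(C#N)c(C(F)(F)F)c1`, gives 16900 nM
compound 2, `CC(O)(CSc1ccc(S(F)(F)(F)(F)F)cc1)C(=O)Nc1ccc([N+](=O)[O-])c(C(F)(F)F)c1`, gives 8700 nM
compound 3, `CC1(C)C(=O)N(c2ccc([N+](=O)[O-])c(C(F)(F)F)c2)C(=S)N1c1cccc(S(F)(F)(F)(F)F)c1`, gives 100000 nM

Compounds 1 and 2 share one core; compound 3 has another, and the difference between the two cores is not broken down here. Compound 3 stands highest of the three, beyond the scatter against both others. Within the shared core of compounds 1 and 2 a single change is made, (cyano in place of nitro on an aromatic carbon), and it produces a 1.9-fold higher number from compound 2 to compound 1 (0.29 log units; within the scatter).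

Compound 4, `CC1(C)C(=O)N(c2ccc(C#N)c(C(F)(F)F)c2)C(=S)N1c1cccc(S(F)(F)(F)(F)F)c1`, arises from compound 3 by cyano in place of nitro on an aromatic carbon. The two place descriptions match word for word, so this is the same change. The step of no change at the digits printed from compound 3 to compound 4 (within the scatter) is expected, resting on a 1.9-fold higher number from compound 2 to compound 1 (0.29 log units; within the scatter) on the other core. Compound 4 is thus estimated at 100000 nM, from 40000 nM to 250000 nM; since compound 3 already sits so high, a reported limit rather than a number is quite possible.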

Compound 4, half-maximal inhibitory concentration: 6900 nM
Compound 4: the middle estimate sits 14-fold (1.16 log units) above what was measured, outside the stated range (below it).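

In this assay, the step of a 14-fold lower number from compound 3 to compound 4 (1.16 log units; beyond the scatter) shows that cyano in place of nitro on an aromatic carbon does not carry over with the same size between the two cores: the same change on two cores in this assay, a 1.9-fold higher number (0.29 log units; within the scatter) from compound 2 to compound 1 and a 14-fold lower number (1.16 log units; beyond the scatter) from compound 3 to compound 4, 28-fold (1.45 log units) apart, beyond the scatter of two such steps

For the compounds shown here, each core supplies only one pair, so the size of the step on the core of compound 1 gave no reliable guide to its size on the core of compound 3. These two pairs do not show which structural difference between the cores accounts for the gap, nor do they give a rule for any further core.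

The compounds shown leave open how an amine or a carboxylic acid at the same place would read on either core. They also leave open which of the two steps a third core would resemble, if either.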